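Replacing 1H-imidazol-1-yl with (dimethylamino)methyl on the chain

The source may report more compounds than this note shows. Statements on the series, on what has been measured and on what is new or still open speak of the compounds shown alone.

In a functional assay on ECa-109 cells (Homo sapiens) for antiproliferative activity, read by MTT assay, with a stated time of 48 h (on this read-out higher numbers stand for weaker inhibition and lower numbers for stronger inhibition), compound 1 `Cn1cc(C2=C(c3nn(CCCN4CCCCC4)c4ncccc34)C(=O)N(c3ccccc3)C2=O)c2ccccc21` gives 12300 nM. Compound 2 `Cn1cc(C2=C(c3nn(CCn4ccnc4)c4ncccc34)C(=O)N(c3ccccc3)C2=O)c2ccccc21` gives 8770 nM, which places it level with compound 1. Compound 3 `Cn1cc(C2=C(c3nn(CCCn4ccnc4)c4ncccc34)C(=O)NC2=O)c2ccccc21` gives > 100000 nM, which is a limit of the assay and not a number.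

Compound 4 `CN(C)CCCn1nc(C2=C(c3cn(C)c4ccccc34)C(=O)N(c3ccccc3)C2=O)c2cccnc21` departs from compound 2 by (dimethylamino)methyl in place of 1H-imidazol-1-yl on a saturated chain carbon, two bonds along the chain from an aromatic nitrogen. Going by the values given here, the one measured step at this place is a 1.4-fold lower number from compound 1 to compound 2 (0.15 log units; within the scatter), which exchanged (piperidin-1-yl)methyl for 1H-imidazol-1-yl. On that evidence, no shift beyond the scatter is expected in this assay, and the estimated step is a 1.1-fold higher number from compound 2 to compound 4 (0.06 log units; within the scatter). Compound 4 is expected at 10000 nM, within a range of 4000 nM to 25000 nM.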

Compound 4, half-maximal inhibitory concentration: 5840 nM
Compound 4: middle estimate off by 1.7-fold (0.23 log units), on the high side; low and high end bracket the measured number.
By their numbers in this assay, from the lowest: compounds 4, 2 and 1 (each within the scatter of the next, the first and the last beyond it). At a limit, above all of these: compound 3.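

Exchanging 2-(1H-imidazol-1-yl)ethyl for 3-(dimethylamino)propyl in this assay gives a 1.5-fold lower number from compound 2 to compound 4 (0.18 log units; within the scatter), so at this place an open-chain end group does as well as an aromatic ring. Going by these compounds alone, exchanging piperidin-1-yl for dimethylamino on the same chain gives a 2.1-fold lower number from compound 1 to compound 4 (0.32 log units; beyond the scatter), the only step at this place that passes the scatter, and only modestly. Nothing measured here explains these numbers. On these data alone, whether a morpholine or a primary amine at the chain end, or a longer chain, would hold or shift the number remains open.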